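A few compounds are considered here, and "the series" means these few. Any claim that something is new, unique, unknown or untested is made for them only; others in the source may bear on it.

Measured in a physicochemical assay for solubility, measured as thermodynamic solubility, at pH 7.4 (on this read-out lower numbers stand for lower solubility and higher numbers for higher solubility), each entry a limit of the assay and not a number:

- compound 1 `CC(=O)NC1CCN(c2nc(NC(c3ccccc3)c3ccccc3)c3c(n2)C(=O)N(C(C)C)C3)C1`: < 1000 nM
- compound 2 `COCCNc1nc(NC(c2ccccc2)c2ccccc2)c2c(n1)C(=O)N(C(C)C)C2`: < 1000 nM
- compound 3 `CC(C)N1Cc2c(NC(c3ccccc3)c3ccccc3)nc(N3CCN(S(C)(=O)=O)CC3)nc2C1=O`: < 1000 nM

Compound 3 therefore has no numerical standing, and all that is available is the limit of < 1000 nM in this assay, at which 3 of the 3 values shown sit.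

Compound 4 `CC(C)N1Cc2c(NC(c3ccccc3)c3ccccc3)nc(N3CCN(C(=O)CN(C)C)CC3)nc2C1=O` has not yet been measured. It carries ((dimethylamino)methyl)carbonyl in place of methylsulfonyl on an amine nitrogen in a ring.

The measured changes at this part of the molecule give no size to carry over. They are a step that the two limits leave unreadable from compound 1 to compound 3, a step that the two limits leave unreadable from compound 2 to compound 3 and a step that the two limits leave unreadable from compound 1 to compound 2. Three different groups thus end at the same limit, so the expectation for compound 4 stays close to it, although the limit leaves the upward side open and the range is wide on that side.

The expected step is a number no lower from compound 3 to compound 4 (the limit leaves the size open).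

Compound 4 is estimated at 1000 nM, with an expected range from 300 nM to 20000 nM.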

Compound 4, solubility: 50000 nM
For compound 4 the middle estimate is 50-fold (1.70 log units) below the measured one, outside the stated range (above it).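

In this assay, this position turns out to be able to carry a large change: ((dimethylamino)methyl)carbonyl in place of methylsulfonyl on the amine nitrogen in the ring gives an at least 50-fold higher number from compound 3 to compound 4 (1.69 log units; beyond the scatter). The 4-(((dimethylamino)methyl)carbonyl)piperazin-1-yl group likewise gives an at least 50-fold higher number from compound 2 to compound 4 (1.69 log units; beyond the scatter) against (2-methoxyethyl)amino, and an at least 50-fold higher number from compound 1 to compound 4 (1.69 log units; beyond the scatter) against 3-acetamidopyrrolidin-1-yl. The steps among compound 1, compound 2 and compound 3 cannot be read, and compound 4 is the only one with a number rather than a limit: the limit of < 1000 nM in this assay, at which 3 of the 4 values shown sit.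

The compounds shown do not separate the dimethylamino group from the carbonyl that carries it. An acetyl group on the same piperazine nitrogen, or a longer chain between the carbonyl and the amine, would show which part goes with the step.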